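Hexylamino in Place of Chloro: Expected Cytotoxicity

The source may hold more compounds than are shown below. What is called first, only, known or untested is meant among the compounds shown, and "the series" means these compounds.

Three compounds share one core. Compound 1 `CCCCNc1nccnc1C(=O)NCc1ccccc1` carries a butylamino group; in an ADME assay on HEL cells (Homo sapiens) for cytotoxicity, read by microscopy, with a stated time of 6 days (on this read-out higher numbers stand for lower toxicity in this test and lower numbers for higher toxicity in this test), compound 1 gives > 100000 nM, which is a limit of the assay. Compound 2 `O=C(NCc1ccccc1)c1nccnc1Cl` bears chloro, and in this assay compound 2 shows "not determined" (no result reported), so no number places it on the scale. Within the data shown here, the only further value shown, that of compound 1, is the limit of > 100000 nM in this assay, at which 1 of the 2 values shown sits. Compound 3 `CCCCCCNc1nccnc1C(=O)NCc1ccccc1` arises through (hexylamino in place of chloro on an aromatic carbon). Among the measured compounds shown here, no measured step in this assay sets a size or direction for this change, and no shift beyond the scatter is expected in either direction. Compound 3 is estimated at 100000 nM, between 30000 nM and 300000 nM, most likely again as a limit.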

Compound 3, minimum cytotoxic concentration: 100000 nM
Compound 3: middle estimate and measured number agree at the digits printed; the measured number falls inside the stated range.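

In this assay compound 3 gives 100000 nM as a true number, the first for an amino chain at this position. Ethyl in place of hydrogen on a saturated chain carbon, which turns butylamino into hexylamino, gives a number no higher from compound 1 to compound 3 (the limit leaves the size open) and so fixes a direction but no size. Compound 1 remains a limit of the assay: the limit of > 100000 nM in this assay, at which 1 of the 3 values shown sits.

The compounds shown leave open whether a longer chain, a cyclic amine or a carboxylic acid at this position would give lower numbers. Compound 2, with chloro, still offers no number for comparison.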